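A Ring Contraction and a Chlorine on the Side Chain

The compounds below may be only part of what the source reports. "The series", "measured", "known", "first", "only" and "open" are said of these compounds alone.

Two compounds have been measured in an assay on isolated protein for binding affinity to 5-hydroxytryptamine receptor 1B (Rattus norvegicus); a lower number here means a stronger inhibitor, a higher number a weaker inhibitor:
compound 1 `c1ccc2c(c1)CC(CCN1CCN(c3cccc4c3OCCO4)CC1)C2` gives 692 nM;
compound 2 `C1=C(CCN2CCN(c3cccc4c3OCCO4)CC2)c2ccccc2C1` gives 251 nM.

Among the compounds with values here, compound 2 stands at the lower of the two numbers in this assay, and its only neighbour is compound 1, from which it is separated by the step of a 2.8-fold lower number from compound 1 to compound 2 (0.44 log units; beyond the scatter), a modest shift that nonetheless lies beyond the scatter. Compound 3 `Clc1cccc2c1CC2CCN1CCN(c2cccc3c2OCCO3)CC1` has not yet been measured. It differs from compound 2 by a group of 9 heavy atoms (8 carbon, 1 chlorine; one four-membered non-aromatic ring of carbon only, one six-membered aromatic ring of carbon only) in place of a group of 9 heavy atoms (9 carbon; one five-membered non-aromatic ring of carbon only, one six-membered aromatic ring of carbon only), on a saturated chain carbon, two bonds along the chain from an amine nitrogen in a ring. The single measured step bears on this only loosely: it exchanged one group for another at the same place on the chain and moved the number modestly, but compound 3 changes both the ring size and adds a chlorine, so no step of the shown kind matches it closely. A step somewhat toward a higher number is expected, with wide uncertainty; compound 3 is therefore estimated at 500 nM in this assay, between 150 nM and 1800 nM, corresponding to an expected step of a 2.0-fold higher number from compound 2 to compound 3 (0.30 log units; within the scatter).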

Compound 3, inhibition constant: 708 nM
The estimate for compound 3 lay 1.4-fold (0.15 log units) below the measured number; measured number inside the range.
By their numbers in this assay, from the lowest: compound 2; then compounds 1 and 3 (each within the scatter of the next).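

In this assay, the group with the four-membered non-aromatic ring and the chlorine does not keep the position of the double-bond group it replaces, giving a 2.8-fold higher number from compound 2 to compound 3 (0.45 log units; beyond the scatter). Against the saturated five-membered group it shows no separable difference, with a 1.0-fold higher number from compound 1 to compound 3 (0.01 log units; within the scatter), so among the three groups seen on this saturated chain carbon, only the one in compound 2 stands apart from the other two. Nothing shown gives a reason for these numbers.

From the compounds shown here alone, the ring size and the chlorine change together here, so what the four-membered ring does without the chlorine, and what the chlorine does on the five-membered ring, remain open. Also open, going by these compounds, is whether a fluorine in place of the chlorine, or a longer chain to the ring amine nitrogen, would move the number.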